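The compounds below may be only part of what the source reports. "The series", "measured", "known", "first", "only" and "open" are said of these compounds alone.

Measured compounds:
- Compound 1, `O=C(CSc1nc(Nc2ccccc2)c2ccccc2n1)Nc1ccc(Br)cc1`: in a functional assay on MGC-803 cells (Homo sapiens) for inhibition, read by MTT assay, with a stated time of 72 h (on this read-out lower numbers stand for stronger inhibition and higher numbers for weaker inhibition), compound 1 gives 19300 nM
- Compound 2, `C=CC(=O)Nc1cccc(NC(=O)CSc2nc(Nc3ccccc3Br)c3ccccc3n2)c1`: in this assay compound 2 gives 12800 nM

Within the data shown here, compound 2 has the lowest of the two numbers so far in this assay, but compound 1 sits within the usual scatter of it, so the two values cannot be told apart and neither compound can be called the more potent of the pair.

The step under consideration leads from compound 2 to compound 3, `C=CC(=O)Nc1cccc(NC(=O)CSc2nc(Nc3cccc(OC)c3)c3ccccc3n2)c1`. The change is 3-methoxyphenyl in place of 2-bromophenyl on a nitrogen on an aromatic ring. Among the measured compounds shown here, no two measured compounds differ from each other in a single place, so the size of this kind of change cannot be read from the numbers at hand; the only comparison, between compound 1 and compound 2, shows two values within the scatter.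

For compound 3 the expectation is therefore a step of modest size, most likely not beyond the scatter, in either direction: a 1.1-fold lower number from compound 2 to compound 3 (0.03 log units; within the scatter). Compound 3 is expected to give about 12000 nM in this assay, with a range from 4000 nM to 40000 nM.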

Compound 3, half-maximal inhibitory concentration: 24200 nM
Compound 3: middle estimate off by 2.0-fold (0.30 log units), on the low side; the measured number falls inside the stated range.
By their numbers in this assay, from the lowest: compounds 2, 1 and 3 (each within the scatter of the next).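

Among these compounds, this is the first pair that differs in a single place, so it gives the first direct reading of the group on this nitrogen: in this assay the change reads a 1.9-fold higher number from compound 2 to compound 3 (0.28 log units; within the scatter). The exchange of 2-bromophenyl for 3-methoxyphenyl swaps a ring carrying bromine for one carrying a methoxy group and adds one hydrogen-bond acceptor, yet compound 2 and compound 3 cannot be told apart on this read-out, so for this pair neither the identity nor the placement of the ring substituent registers as a difference in potency. Nothing available explains why the two values lie as close as they do.

Open, as far as these compounds go, is whether any group on this nitrogen can move the number beyond the scatter, for example a carboxylic acid or an amine on the phenyl ring, or a longer chain in place of that ring. Also open, from the compounds shown here alone, is how bromine and methoxy each behave on their own, since this single pair changes both the substituent and its place on the ring at once.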